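A few compounds are considered here, and "the series" means these few. Any claim that something is new, unique, unknown or untested is made for them only; others in the source may bear on it.

Compound 1 `CCNC(=O)c1nc(-c2cc(OC)c(OC)c(OC)c2)n(-c2ccc(OC)cc2)n1` stands at the top of the two numbers measured in a functional assay on the whole organism for inhibition, with Rattus norvegicus as the target, read by paw edema, with stated times of 30 min and 3 h, at a dose of 0.28 mmol/kg by the oral route (a lower number here means less inhibition, a higher number more inhibition at the dose given (going by the name of the read-out)), where compound 1 gives 69%. Its nearest neighbour is compound 2 `COc1ccc(-n2nc(C(=O)Nc3ccc(C(F)(F)F)cc3)nc2-c2cc(OC)c(OC)c(OC)c2)cc1`, which in this assay gives 65%; the step of a number 4 percentage points lower from compound 1 to compound 2 (within the scatter) lies within the scatter of repeated measurements. Compound 3 `COc1ccc(-n2nc(C(=O)Nc3ccc(O)cc3)nc2-c2cc(OC)c(OC)c(OC)c2)cc1` is not yet measured, and it differs from compound 1 by 4-hydroxyphenyl in place of ethyl on an amide-type nitrogen. Within the data shown here, the one measured step that bears on this change is the one from compound 1 to compound 2, where an aryl group also replaced the ethyl on the amide-type nitrogen, and that step of a number 4 percentage points lower from compound 1 to compound 2 (within the scatter) was small. On that basis a step of similar size, or none beyond the scatter, is expected for a number 4 percentage points lower from compound 1 to compound 3 (within the scatter). Compound 3 is therefore estimated to give 65% in this assay, with a range from 52% to 78%.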

Compound 3, a percentage reported as inhibition, in the whole organism at one dose (the size of the read-out at that dose, not a potency): 50%
Compound 3: middle estimate off by 15 percentage points, on the high side, and the stated range ends above it.
By their numbers in this assay, from the lowest: compound 3; then compounds 2 and 1 (each within the scatter of the next).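

In this assay, an aryl group on the amide-type nitrogen proves not to be interchangeable with ethyl: the change to 4-hydroxyphenyl gives a number 19 percentage points lower from compound 1 to compound 3 (beyond the scatter), whereas the change to 4-(trifluoromethyl)phenyl gave only a number 4 percentage points lower from compound 1 to compound 2 (within the scatter). With the aryl group kept and hydroxy in place of trifluoromethyl on an aromatic carbon, the result is a number 15 percentage points lower from compound 2 to compound 3 (beyond the scatter), so among these compounds the lower number goes with the hydroxy group and not with the aryl group as such. Nothing measured here explains this difference.

On these data alone, it remains open whether a methoxy group, an amine or a carboxylic acid on that aromatic carbon would give a number like that of compound 3 or like that of compound 2. Also open, as far as these compounds go, is how a longer chain, such as propyl or butyl, would compare with ethyl on the amide-type nitrogen.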